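The source may report more compounds than this note shows. Statements on the series, on what has been measured and on what is new or still open speak of the compounds shown alone.

Compound 1 `N#Cc1c(Nc2ccc([N+](=O)[O-])cc2)sc2ccccc12`: 8%
Compound 2 `COc1ccc(Nc2sc3c(OC)cc(OC)cc3c2C#N)cc1`: 63%

In a functional assay on HUVEC cells (Homo sapiens), read by fluorescence and microscopy, with a stated time of 6 h, tested at 10 uM (a higher number here means a weaker effect of the compound at the concentration tested, a lower number a stronger effect), compound 1 gives 8%, the lower of the two numbers; in this assay compound 2 gives 63%, a gap beyond the usual scatter. Compound 3 `N#Cc1c(Nc2ccc(O)cc2)sc2ccccc12` differs from compound 1 by hydroxy in place of nitro on an aromatic carbon. Within the data shown here, no measured pair shows a change of this kind, so the expected step from compound 1 to compound 3 is uncertain; a moderate rise in the number, beyond the scatter, is expected, a number 27 percentage points higher from compound 1 to compound 3 (beyond the scatter). For compound 3 in this assay the estimate is 35%, with a range from 10% to 70%.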

Compound 3, a percentage reported as activity, at one concentration (the size of the read-out at that concentration, not a potency): 25%
For compound 3 the middle estimate is 10 percentage points above the measured one; the range from low to high includes it.
By their numbers in this assay, from the lowest: compound 1; then compound 3; then compound 2.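

In this assay, among these compounds, putting hydroxy in place of nitro on the aromatic carbon para to a large group gives a number 17 percentage points higher from compound 1 to compound 3 (beyond the scatter), the first step here that isolates a single place. The effect at the concentration tested therefore depends on the group at this position, but it weakens only modestly and is not lost with this change. Nothing available accounts for the step. As far as these compounds go, how an amine or a carboxylic acid at this position would compare remains open. So does whether the nitro and hydroxy groups would give a similar step on another carbon of this ring.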